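The source may hold more compounds than are shown below. What is called first, only, known or untested is meant among the compounds shown, and "the series" means these compounds.

Values in a functional assay on T-24 cells (Homo sapiens) for antiproliferative activity, read by MTT assay, with a stated time of 48 h (a lower number here means a stronger inhibitor, a higher number a weaker inhibitor), for the measured compounds:

compound 1 `Cc1ccc(NC(=O)Nc2cccc(CNc3nccnc3Cl)c2)cc1` gives 9820 nM
compound 2 `O=C(Nc1cccc(CNc2nccnc2Cl)c1)Nc1ccccc1Cl` gives 6680 nM
compound 3 `O=C(Nc1ccccc1)Nc1cccc(CNc2nccnc2Cl)c1` gives 19800 nM

Compound 3 holds the highest number of the three. Going by the values given here, the gap to compound 1 is within the scatter, so no order between those two can be read; the gap to compound 2 is beyond it, and the step of a 3.0-fold higher number from compound 2 to compound 3 (0.47 log units; beyond the scatter) is the one measured change that clears the scatter. The step of a 2.0-fold higher number from compound 1 to compound 3 (0.30 log units; within the scatter), by contrast, stays inside it.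

Compound 4 `O=C(Nc1cccc(CNc2nccnc2Cl)c1)Nc1ccccc1F` differs from compound 3 by fluoro in place of hydrogen on an aromatic carbon. The bearing step is the chloro case: a chloro at this position in compound 2 gives a number beyond the scatter lower than compound 3. A fluoro at the same place is a smaller substituent, and no fluoro case is measured in the series, so the size of its effect cannot be read directly. The expectation is a lowering of the number that is at most modest, likely smaller than the chloro step and possibly within the scatter: for compound 4 the estimated step is a 1.7-fold lower number from compound 3 to compound 4 (0.22 log units; within the scatter). Compound 4 is expected to give about 12000 nM, between 5500 nM and 28000 nM.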

Compound 4, half-maximal inhibitory concentration: 7450 nM
For compound 4 the middle estimate is 1.6-fold (0.21 log units) above the measured one, and the stated range covers the measured number.
By their numbers in this assay, from the lowest: compounds 2, 4, 1 and 3 (each within the scatter of the next, the first and the last beyond it).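

In this assay, fluoro on the aromatic carbon ortho to a large group gives a 2.7-fold lower number from compound 3 to compound 4 (0.42 log units; beyond the scatter) and thus adds a second halogen case to chloro in compound 2, both clearing the scatter against the unsubstituted phenyl of compound 3. The exchange of the two halogens is a 1.1-fold higher number from compound 2 to compound 4 (0.05 log units; within the scatter) and leaves no order between compound 2 and compound 4, so the gain over hydrogen at this position does not separate fluoro from chloro. The change to 2-fluorophenyl from 4-methylphenyl is a 1.3-fold lower number from compound 1 to compound 4 (0.12 log units; within the scatter) and likewise sets no order between those two compounds.

From the compounds shown here alone, whether a methoxy, a trifluoromethyl or an amine at this same place would match the two halogens stays open. Nothing at hand explains the lower numbers of the halogen compounds.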